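The source may hold more compounds than are shown below. What is called first, only, known or untested is meant among the compounds shown, and "the series" means these compounds.

Of the compounds shown here, three of one series have been tested in a functional assay on HeLa cells (Homo sapiens) for cytotoxicity, read by MTT assay, with a stated time of 24 h; on this read-out lower numbers stand for stronger inhibition and higher numbers for weaker inhibition. Compound 1, `O=C(NC(=S)Nc1nc2cc(Br)ccc2s1)N1CCOCC1`, gives 38900 nM. Compound 2, `CCCCC(=O)NC(=S)Nc1nc2cc(Br)ccc2s1`, gives 60200 nM. Compound 3, `CCCCC(=O)NC(=S)Nc1nc2ccccc2s1`, gives 56700 nM. The two cores differ only in the way hydrogen in place of bromo on an aromatic carbon describes, and the step that goes with it, a 1.1-fold lower number from compound 2 to compound 3 (0.03 log units; within the scatter), is small. The change from compound 2 to compound 1 is morpholin-4-yl in place of butyl on a carbonyl carbon, and it produced a 1.5-fold lower number from compound 2 to compound 1 (0.19 log units; within the scatter).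

Compound 4, `O=C(NC(=S)Nc1nc2ccccc2s1)N1CCOCC1`, has not been measured. It differs from compound 3 as morpholin-4-yl in place of butyl on a carbonyl carbon. Among the measured compounds shown here, this is the same change as the one between compound 2 and compound 1: the group that leaves, the group that enters and the place where it happens are described in the same words. The only difference between the two pairs is the core, where compound 3 and compound 4 carry hydrogen where compound 2 and compound 1 carry bromo.

For the measured compounds named here, since the one measured instance of this change stayed within the scatter, and the change of core from compound 2 to compound 3 also stayed within the scatter, the expectation for compound 4 in this assay rests on a single precedent. The step from compound 3 to compound 4 is estimated at a 1.4-fold lower number from compound 3 to compound 4 (0.15 log units; within the scatter), matching the earlier one in direction and size. Compound 4 is therefore expected to give about 40000 nM in this assay, with a plausible range from 20000 nM to 80000 nM.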

Compound 4, half-maximal inhibitory concentration: 51800 nM
Compound 4: the middle estimate sits 1.3-fold (0.11 log units) below what was measured; measured number inside the range.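

In this assay, the change from butyl to morpholin-4-yl on the carbonyl carbon now has a second instance, a step of a 1.1-fold lower number from compound 3 to compound 4 (0.04 log units; within the scatter), and the two instances cannot be told apart: the same change on two cores in this assay, a 1.5-fold lower number (0.19 log units; within the scatter) from compound 2 to compound 1 and a 1.1-fold lower number (0.04 log units; within the scatter) from compound 3 to compound 4, 1.4-fold (0.15 log units) apart, within the scatter of two such steps.

The change from bromo to hydrogen on an aromatic carbon also has a second instance, a step of a 1.3-fold higher number from compound 1 to compound 4 (0.12 log units; within the scatter), and the same holds for it: the same change on two cores in this assay, a 1.1-fold lower number (0.03 log units; within the scatter) from compound 2 to compound 3 and a 1.3-fold higher number (0.12 log units; within the scatter) from compound 1 to compound 4, 1.4-fold (0.15 log units) apart, within the scatter of two such steps.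

This shows that, among these four compounds, each change behaves alike on both cores, but only in the modest sense that every step is too small to separate from the ordinary spread of repeated measurements, so it does not show that either change has a real effect on this read-out or that a real effect would carry from one core to another.

The compounds shown leave open whether any other group on the carbonyl carbon, such as a longer chain like octyl or an amine like piperazin-1-yl, would give a step that stands clear of the scatter. They also leave open whether a group other than bromo or hydrogen on the aromatic carbon, such as methoxy or a carboxylic acid, would do so, and whether such a step would then hold on both cores.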